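Working notes on the shared core: compound 2 to compound 3

A few compounds are considered here, and "the series" means these few. Any claim that something is new, unique, unknown or untested is made for them only; others in the source may bear on it.

Measured so far:
compound 1, `Cc1ccc(S(=O)(=O)Oc2ccc3c(c2C)[C@H](Cn2cc(-c4ccc(Br)cc4)nn2)[C@@]24CC(=O)[C@@](C)(CC[C@@H]32)C4)cc1`: in a functional assay on MCF7 cells (Homo sapiens) for cytotoxicity, read by MTT assay, with a stated time of 4 days (on this read-out lower numbers stand for stronger inhibition and higher numbers for weaker inhibition), compound 1 gives > 20000 nM, a limit of the assay rather than a number.
compound 2, `Cc1ccc(-c2cn(C[C@H]3c4c(ccc(OS(=O)(=O)c5ccc(C)cc5)c4C)[C@@H]4CC[C@@]5(C)C[C@]43CC5=O)nn2)cc1`: in this assay compound 2 gives > 20000 nM, again a limit.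

Compound 2 therefore stands at the limit of this assay, with no number attached to it. Compound 1 stands at the same limit. The step from compound 1 to compound 2, a step that the two limits leave unreadable from compound 1 to compound 2, is unreadable because the limit of > 20000 nM in this assay, at which 2 of the 2 values shown sit, covers both of its ends, so no size can be taken from it.

Compound 3, `Cc1ccc(S(=O)(=O)Oc2ccc3c(c2C)[C@H](Cn2cc(-c4ccc(C(F)(F)F)cc4)nn2)[C@@]24CC(=O)[C@@](C)(CC[C@@H]32)C4)cc1`, differs from compound 2 by trifluoromethyl in place of methyl on an aromatic carbon. For the measured compounds named here, the only measured step gives no readable size and bears on this change only by showing that the starting point sits at the limit. No step beyond the scatter can be argued for in either direction from what has been measured.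

Compound 3 is expected to stay at or near the limit, with an estimate of 30000 nM and a range from 12000 nM to 100000 nM. The step that the limit leaves unreadable from compound 2 to compound 3 is accordingly expected to be no more than the scatter, and most likely the assay will again report only a limit.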

Compound 3, half-maximal inhibitory concentration: > 20000 nM
Compound 3 ended at the assay's limit; the forecaster's own chance of this, stated with the estimate: 80%; the middle value does not contradict the limit.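

In this assay, the steps among compound 1, compound 2 and compound 3 cannot be read, and no size can be taken from any of them: the limit of > 20000 nM in this assay, at which 3 of the 3 values shown sit. The compounds shown leave open whether bromo, methyl or trifluoromethyl on this aromatic carbon makes any difference in this assay.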